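Silyl ether in place of diethoxymethyl on the side chain

The source may hold more compounds than are shown below. What is called first, only, known or untested is meant among the compounds shown, and "the series" means these compounds.

Compound 1 `CCOC(CCn1c(Cc2nn(C)c(=O)c3ccccc23)nnc1SCCCCCCCC(=O)Nc1ccc(Cl)cc1Cl)OCC`: 30000 nM
Compound 2 `Cn1nc(Cc2nnc(SCC(=O)Nc3ccc(Cl)cc3Cl)n2CCC(=O)O)c2ccccc2c1=O`: > 30000 nM, a limit of the assay, not a number

Within the data shown here, in an assay on NK92 cells for inhibition of interleukin-15 (Homo sapiens), read by AlphaScreen, with stated times of 30 min and 1 h (on this read-out higher numbers stand for weaker inhibition and lower numbers for stronger inhibition), compound 1 stands at 30000 nM, the only number in the set. Compound 2 sits at the limit (the limit of > 30000 nM in this assay, at which 1 of the 2 values shown sits). Compound 3 `Cn1nc(Cc2nnc(SCCCCCCCC(=O)Nc3ccc(Cl)cc3Cl)n2CCCO[Si](C)(C)C(C)(C)C)c2ccccc2c1=O` carries a group of 9 heavy atoms (7 carbon, 1 oxygen, 1 silicon; no ring) in place of a group of 7 heavy atoms (5 carbon, 2 oxygen; no ring), on a saturated chain carbon, two bonds along the chain from an aromatic nitrogen. Among the measured compounds shown here, no measured step of this kind exists in the set, so nothing beyond the scatter is expected in either direction. For compound 3 the estimate is 30000 nM, with a range of 10000 nM to 100000 nM. This estimate means an expected step of no change at the digits printed from compound 1 to compound 3 (within the scatter), and a limit report is a real possibility.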

Compound 3, half-maximal inhibitory concentration: > 30000 nM
Compound 3: only a limit was reported; the forecaster's own chance of this, stated with the estimate: 50%; the middle value sits exactly at the limit.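

In this assay, placing the group of 9 heavy atoms on a saturated chain carbon, two bonds along the chain from an aromatic nitrogen, in place of diethoxymethyl gives a number no lower from compound 1 to compound 3 (the limit leaves the size open). For compound 3, > 30000 nM is a limit of the assay, not a number. This position therefore shows no gain from the change, and most of the set now stands at the limit: the limit of > 30000 nM in this assay, at which 2 of the 3 values shown sit.

As far as these compounds go, the effect of an amine or a hydroxyl at this place remains open. So does whether any group there can improve on compound 1, at 30000 nM.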